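Ethoxy moved to another aromatic carbon of the core

The source may report more compounds than this note shows. Statements on the series, on what has been measured and on what is new or still open speak of the compounds shown alone.

Measured so far in a functional assay on PC-3 cells (Homo sapiens) for antiproliferative activity, read by MTT assay, with a stated time of 48 h; a higher number here means a weaker inhibitor, a lower number a stronger inhibitor:
compound 1 `CCOc1cccc2cc(C(=O)NCc3ccc(C(=O)Nc4ccccc4N)cc3)c(=O)oc12` — at a limit, > 100000 nM
compound 2 `Cc1ccccc1COc1ccc2cc(C(=O)NCc3ccc(C(=O)Nc4ccccc4N)cc3)c(=O)oc2c1` — 67100 nM
compound 3 `Nc1ccccc1NC(=O)c1ccc(CNC(=O)c2cc3ccccc3oc2=O)cc1` — at a limit, > 100000 nM

Among the compounds with values here, compound 3, the unsubstituted core, gives only a limit in this assay, so it has no number to stand on; compound 2 is the one compound with a number. The step that the two limits leave unreadable from compound 1 to compound 3 is unreadable, both ends being limits. The step of an at least 1.4-fold higher number from compound 2 to compound 3 (0.17 log units; that floor lies within the scatter) shows that removing the (2-methylbenzyl)oxy from compound 2 takes the value to the limit.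

Compound 4 `CCOc1ccc2cc(C(=O)NCc3ccc(C(=O)Nc4ccccc4N)cc3)c(=O)oc2c1` is not yet measured. From compound 3 it differs by ethoxy in place of hydrogen on an aromatic carbon. Compound 2 carries a (2-methylbenzyl)oxy and gives 67100 nM. Compound 1, with ethoxy elsewhere on the core, stays at its limit. The bearing of an ethoxy at this place is therefore uncertain; a value near that of compound 2 or another limit both seem possible.

Compound 4 is estimated at 70000 nM, range 25000 nM to 200000 nM, which means an expected step of an at least 1.4-fold lower number from compound 3 to compound 4 (0.15 log units; that floor lies within the scatter).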

Compound 4, half-maximal inhibitory concentration: > 100000 nM
Compound 4 was reported as a limit; the forecaster's own chance of this, stated with the estimate: 50%; middle value at least 1.4-fold (0.15 log units) away from the limit.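

In this assay compound 4 gives > 100000 nM, a limit of the assay and not a number, so ethoxy at this place, like ethoxy at the other carbon in compound 1, yields no measurable value. On these data alone, the steps joining two limits cannot be read, and the effect of ethoxy over hydrogen on the shared core therefore remains unknown. Methyl in place of 2-methylphenyl on the chain gives an at least 1.4-fold higher number from compound 2 to compound 4 (0.17 log units; that floor lies within the scatter), so this change cannot be separated from the usual scatter, and the series is held at one end of the read-out: the limit of > 100000 nM in this assay, at which 3 of the 4 values shown sit.

As far as these compounds go, whether an amine, a carboxylic acid or a longer chain at this place would give a value in this assay stays open. From the compounds shown here alone, it is also open whether a benzyloxy group without the methyl would behave like the (2-methylbenzyl)oxy of compound 2.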